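This account rests on a few compounds, and the source may have more. Where it says the series, first, only, none or still open, it means among the compounds named here.

Compound 1 `Nc1cc(N)c2nc(-c3ccccc3)c(Sc3ccc(F)cc3)nc2c1`: 20900 nM
Compound 2 `COc1cc(CNc2nc3cc(N)cc(N)c3nc2-c2ccccc2)cc(OC)c1OC`: 479 nM
Compound 3 `COc1ccc(CNc2nc3cc(N)cc(N)c3nc2-c2ccccc2)cc1`: 13200 nM

Of the compounds shown here, three on a shared core have been measured in a functional assay on KM12 cells (Homo sapiens) for inhibition, read by sulforhodamine B assay, with a stated time of 48 h; a lower number here means a stronger inhibitor of growth, a higher number a weaker inhibitor of growth. Compound 1 gives the highest number of the three. Compound 3 lies within the scatter of compound 1, so the two cannot be ordered. Compound 2 stands well apart, with a number far lower than that of compound 1, a gap beyond the scatter; compound 2 differs from compound 1 in more than one place, so no single change can be read from that gap.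

The step to compound 4 `COc1ccc(Sc2nc3cc(N)cc(N)c3nc2-c2ccccc2)cc1` is confined to the (4-fluorophenyl)sulfanyl group: methoxy in place of fluoro on an aromatic carbon. Among the measured compounds shown here, no measured pair shows this change, so its direction is open. Compound 3 carries a methoxy on a ring joined through another link and gives 13200 nM, which offers no hint of a large gain. Compound 4 is therefore expected to show a step of a 1.7-fold lower number from compound 1 to compound 4 (0.24 log units; within the scatter), within or barely beyond the scatter. The estimate for compound 4 in this assay is 12000 nM, from 3000 nM to 40000 nM.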

Compound 4, concentration for 50% growth inhibition: 28200 nM
Estimate against measurement, compound 4: 2.4-fold (0.37 log units) below; the range from low to high includes it.
By their numbers in this assay, from the lowest: compound 2; then compounds 3, 1 and 4 (each within the scatter of the next, the first and the last beyond it).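

In this assay, among the compounds shown here, compound 1 and compound 4 form the first pair on the shared core that differs in one place, and the pair gives a 1.3-fold higher number from compound 1 to compound 4 (0.13 log units; within the scatter). Methoxy in place of fluoro on this aromatic carbon, para to a large group, therefore produces no change that can be read. The earlier compounds shown here could not provide this result. For the compounds shown here, no pair among them differed in only one place. Nothing available here accounts for this result.

Whether any other group at this position would move the number remains open, since an amine or a carboxylic acid in place of the fluoro has no value among the compounds shown. Compound 2 and compound 3 differ in more than one place, so what separates their numbers also remains unresolved.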